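Amino in place of hydroxy on the shared core

A few compounds are considered here, and "the series" means these few. Any claim that something is new, unique, unknown or untested is made for them only; others in the source may bear on it.

For the measured compounds named here, compound 1 `CN(C)CCCNc1c(C(=O)NCc2ccc(F)cc2)nc(Br)c2cccnc12` alone carries a number so far: in a functional assay on MCF7 cells (Homo sapiens) for cytotoxicity, read by MTT assay, with a stated time of 72 h (on this read-out higher numbers stand for weaker inhibition and lower numbers for stronger inhibition), compound 1 gives 7000 nM as its reading. Compound 2 `O=C(NCc1ccc(F)cc1)c1nc(Br)c2cccnc2c1NCCO` has no place on that scale, its entry being "not determined" (no result reported) with nothing further. Compound 3 `NCCNc1c(C(=O)NCc2ccc(F)cc2)nc(Br)c2cccnc12` differs from compound 2 by amino in place of hydroxy on a saturated chain carbon, two bonds along the chain from a nitrogen on an aromatic ring on the same core. Going by the values given here, no step can be anchored on compound 2. In this assay compound 1 stands at 7000 nM in this read-out, and the usual scatter is expected to cover any shift from that level in either direction. Compound 3 is expected at 6000 nM with an estimated range from 2000 nM to 20000 nM in this assay.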

Compound 3, half-maximal inhibitory concentration: 6000 nM
Compound 3: the middle estimate sits on the measured number at the digits printed; low and high end bracket the measured number.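

In this assay the exchange of (dimethylamino)methyl for amino on this saturated chain carbon gives a 1.2-fold lower number from compound 1 to compound 3 (0.07 log units; within the scatter), so the shorter (2-aminoethyl)amino chain of compound 3 holds the level of compound 1 in this series. The step between compound 2 and compound 3 cannot be read: compound 2 has no number. No measurement shown here offers an explanation for the result.

As far as these compounds go, how hydroxy compares with amino at this carbon stays open. So does the reading of a carboxylic acid or a longer chain in the same place.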